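The compounds below may be only part of what the source reports. "The series", "measured", "known", "first", "only" and "open" are said of these compounds alone.

Working notes on the series. Compound 1 `C#CCSc1nc(N/N=C/c2cc(OC)c(OC)c(OC)c2)c2nnn(Cc3ccccc3)c2n1` in a functional assay on ECa-109 cells (Homo sapiens) for antiproliferative activity, read by MTT assay, with a stated time of 72 h (a lower number here means a stronger inhibitor, a higher number a weaker inhibitor), gives 6540 nM. Compound 2 `CCCSc1nc(N/N=C/c2c(O)ccc3ccccc23)c2nnn(Cc3ccccc3)c2n1` gives in this assay 9290 nM; the two numbers lie within the scatter of each other, so neither is placed ahead of the other. Compound 3 `CCCSc1nc(N/N=C/c2ccccc2)c2nnn(Cc3ccccc3)c2n1` reaches only (the limit of > 64000 nM in this assay, at which 1 of the 3 values shown sits), so its entry > 64000 nM is a limit and not a number. Among the measured compounds shown here, the one measured step, an at least 6.8-fold higher number from compound 2 to compound 3 (0.83 log units; beyond the scatter), concerns the aryl on the carbon double-bonded to nitrogen.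

The next compound, compound 4 `COc1cc(/C=N/Nc2nc(SCc3ccccc3)nc3c2nnn3Cc2ccccc2)cc(OC)c1OC`, differs from compound 1 at another place: phenyl in place of ethynyl on a saturated chain carbon bound to a sulfur. For the measured compounds named here, no measured step touches the group on the sulfur, so the step from compound 2 to compound 3 gives no direct guide here, and the unchanged trimethoxyphenyl hydrazone of compound 1 is kept. The change is therefore expected to stay within the scatter, with a 1.2-fold lower number from compound 1 to compound 4 (0.08 log units; within the scatter) as the estimated step. For compound 4 the estimate in this assay is 5500 nM, between 2000 nM and 16000 nM.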

Compound 4, half-maximal inhibitory concentration: 4400 nM
Beside the measured number, compound 4's estimate is 1.3-fold (0.10 log units) above it; the range from low to high includes it.
By their numbers in this assay, from the lowest: compounds 4, 1 and 2 (each within the scatter of the next, the first and the last beyond it). At a limit, above all of these: compound 3.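

With the trimethoxyphenyl hydrazone held fixed, the group on the sulfur can now be read directly in this assay: the step from propargylsulfanyl to benzylsulfanyl is a 1.5-fold lower number from compound 1 to compound 4 (0.17 log units; within the scatter), so the two groups are not separated. On a saturated chain carbon bound to a sulfur, ethynyl and phenyl therefore give values within the scatter of each other, though this rests on this single pair and extends to no other hydrazone. Nothing shown bears on why the two groups read alike.

No pair shown links the propyl on the sulfur in compound 2 directly to the propargyl of compound 1 or the benzyl of compound 4. As far as these compounds go, how an amine, a carboxylic acid or a longer chain would read at this position also stays open.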